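Nitro in place of carbamoyl: solubility working notes

A few compounds are considered here, and "the series" means these few. Any claim that something is new, unique, unknown or untested is made for them only; others in the source may bear on it.

Measured so far in a physicochemical assay for solubility, with a stated time of 4 h, at pH 7.4; a higher number here means a more soluble compound, a lower number a less soluble compound (two compounds):
- compound 1 (`Cc1cc(/C=C/C#N)cc(C)c1Oc1cc(Nc2ccc(C#N)cc2)c(N)cc1C(N)=O`) at 0.63 ug/mL
- compound 2 (`CNC(=O)c1cc(N)c(Nc2ccc(C#N)cc2)cc1Oc1c(C)cc(CCC#N)cc1C`) at 8.28 ug/mL

Compound 1 stands lowest of these two numbers, and compound 2 lies above it by more than the usual scatter. The unmeasured compound 3 (`Cc1cc(/C=C/C#N)cc(C)c1Oc1cc(Nc2ccc(C#N)cc2)c(N)cc1[N+](=O)[O-]`) has nitro in place of carbamoyl on an aromatic carbon of the core of compound 1 (nitro in place of carbamoyl on an aromatic carbon). The position is para to a (4-cyanophenyl)amino group and meta to an amino group. Within the data shown here, no measured pair shows this change in isolation, so the expectation stays with compound 1 at 0.63 ug/mL as its starting point. In this assay no step beyond the scatter is expected, in either direction. The expected step of a 1.3-fold lower number from compound 1 to compound 3 (0.10 log units; within the scatter) is therefore small. Compound 3 is estimated at 0.5 ug/mL, with an expected range from 0.15 ug/mL to 1.7 ug/mL.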

Compound 3, solubility: 0.29 ug/mL
Estimate against measurement, compound 3: 1.7-fold (0.24 log units) above; low and high end bracket the measured number.
By their numbers in this assay, from the lowest: compound 3; then compound 1; then compound 2.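

In this assay, among these compounds, nitro in place of carbamoyl on this aromatic carbon, para to a (4-cyanophenyl)amino group and meta to an amino group, gives a 2.2-fold lower number from compound 1 to compound 3 (0.34 log units; beyond the scatter) and is the only step read at this position. The position therefore responds to this exchange, modestly and downward, from a starting number already at the low end of the series. The exchange swaps groups of equal heavy-atom count, removes the hydrogen-bond donor of carbamoyl and adds a hydrogen-bond acceptor, but no measurement of any property of the two groups bears on the step.

From the compounds shown here alone, whether a carboxylic acid or an aminomethyl group at this position would raise the number remains open. Also open, going by these compounds, is whether nitro in place of carbamoyl gives a step of similar size when other groups on the shared core differ.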